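A few compounds are considered here, and "the series" means these few. Any claim that something is new, unique, unknown or untested is made for them only; others in the source may bear on it.

Three compounds carry the same basic arrangement: a piperazine bearing an aromatic ring at one end and, at the other, a three-carbon chain leading to an amino-substituted heteroaromatic ring that carries a dimethylamide. Compound 1 `COc1ccccc1N1CCN(CCCNc2ncc(C#N)cc2C(=O)N(C)C)CC1` gives 0.794 nM in a functional assay for antagonist activity at Alpha-1A adrenergic receptor (Oryctolagus cuniculus); a lower number here means tighter binding, a higher number weaker binding. Compound 2 `COc1ccccc1N1CCN(CCCNc2ccncc2C(=O)N(C)C)CC1` gives 12.6 nM in this assay. Compound 3 `CN(C)C(=O)c1cccnc1NCCCN1CCN(c2ccccc2)CC1` gives 6.31 nM in this assay, which places it second highest of the three numbers; its value and that of compound 2 sit within the usual scatter of each other, so no order between them can be claimed, while compound 1 stands clearly lower, beyond the scatter.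

Compound 4 `CSc1ccccc1N1CCN(CCCNc2ncccc2C(=O)N(C)C)CC1` is the next compound, built from compound 3 by one change: methylsulfanyl in place of hydrogen on an aromatic carbon. Among the compounds with values here, no directly comparable step between measured compounds exists here, so the size of the effect is open. Given that the only compound with a group on that ring, compound 1, reached 0.794 nM, a modest move toward a lower number is expected, though a step no larger than the scatter is just as plausible. The expected step from compound 3 to compound 4 in this assay is a 1.6-fold lower number from compound 3 to compound 4 (0.20 log units; within the scatter). Compound 4 is estimated at 4 nM, with a range from 1.5 nM to 12 nM.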

Compound 4, dissociation constant: 0.631 nM
The estimate for compound 4 lay 6.3-fold (0.80 log units) above the measured number; measured number below the stated range.
By their numbers in this assay, from the lowest: compounds 4 and 1 (each within the scatter of the next); then compounds 3 and 2 (each within the scatter of the next).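

In this assay, replacing hydrogen with methylsulfanyl on an aromatic carbon, ortho to a large group, gives a 10-fold lower number from compound 3 to compound 4 (1.00 log units; beyond the scatter). Within the data shown here, this is the first step here between two compounds that differ in one place, and it shows that this position on the phenyl ring is far from indifferent: a group of only 2 heavy atoms moves the number by more than the usual scatter. No measurement is available here that accounts for the size of this step.

A single substituent at one position cannot show whether the sulfur atom matters or whether other small groups at this place would produce a similar step, so a chlorine atom, an ethylsulfanyl group or a methylsulfonyl group would each test a different part of that question. On these data alone, it also remains open whether the same change would produce a step of similar size on the cores of compound 1 and compound 2, which carry methoxy on that ring and differ elsewhere.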